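The source may report more compounds than this note shows. Statements on the series, on what has been measured and on what is new or still open speak of the compounds shown alone.

Measured in a functional assay on HCT-116 cells (Homo sapiens) for cytotoxicity, read by sulforhodamine B assay, with a stated time of 24 h; a lower number here means a stronger inhibitor, a higher number a weaker inhibitor:
- compound 1 `CC(=O)N/N=C1\C(=O)Nc2ccc(S(=O)(=O)N3CCOCC3)cc21`: 29000 nM
- compound 2 `N/N=C1\C(=O)Nc2ccc(S(=O)(=O)N3CCOCC3)cc21`: 36300 nM
- compound 3 `O=C1Nc2ccc(S(=O)(=O)N3CCOCC3)cc2/C1=N/Nc1ccccc1`: 10500 nM

Compound 3 has the lowest number of these three, though all three numbers are fairly close together. Compound 4 `CC(=O)c1cccc(/N=C2\C(=O)Nc3ccc(S(=O)(=O)N4CCOCC4)cc32)c1` carries 3-acetylphenyl in place of anilino on a double-bonded nitrogen. The closest guides are two steps that put phenyl on an amine nitrogen: a 2.8-fold lower number from compound 1 to compound 3 (0.44 log units; beyond the scatter) and a 3.5-fold lower number from compound 2 to compound 3 (0.54 log units; beyond the scatter). Both are modest. The remaining step, a 1.3-fold higher number from compound 1 to compound 2 (0.10 log units; within the scatter), is smaller still. Compound 4 keeps a six-membered aromatic ring of carbon only, so no large step is expected, and these data suggest no clear direction. The expected step is a 1.1-fold lower number from compound 3 to compound 4 (0.02 log units; within the scatter). For compound 4, the estimate is 10000 nM, with an expected range from 3500 nM to 30000 nM.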

Compound 4, half-maximal inhibitory concentration: 29000 nM
Compound 4: middle estimate off by 2.9-fold (0.46 log units), on the low side; low and high end bracket the measured number.
By their numbers in this assay, from the lowest: compound 3; then compounds 1, 4 and 2 (each within the scatter of the next).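

Replacing anilino with 3-acetylphenyl on this double-bonded nitrogen is not a neutral swap, although both groups hold a six-membered aromatic ring of carbon only (a 2.8-fold higher number from compound 3 to compound 4 (0.44 log units; beyond the scatter)). Compound 4 also cannot be told apart from the compounds with much smaller groups at this position (a 1.3-fold lower number from compound 2 to compound 4 (0.10 log units; within the scatter); no change at the digits printed from compound 1 to compound 4 (within the scatter)), so an aromatic ring here does not alone give the lower number seen for compound 3. No measurement shown offers a reason for this. A plain phenyl group, or a 3-aminophenyl or 3-carboxyphenyl group, at this position could help separate the role of the acetyl from that of the anilino nitrogen.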